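Swapping chloro for fluoro on compound 3

The source may report more compounds than this note shows. Statements on the series, on what has been measured and on what is new or still open speak of the compounds shown alone.

Measured in a functional assay on GBM3 cells (Homo sapiens) for antiproliferative activity, read by WST assay, with a stated time of 72 h; a higher number here means a weaker inhibitor, a lower number a stronger inhibitor:
compound 1 `O=C(Nc1cccc(Cl)c1)Nc1cc2ncncc2cc1OCc1ccccc1Cl`: 2800 nM
compound 2 `O=C(Nc1ccccc1F)Nc1cc2ncncc2cc1OCc1ccccc1`: 5900 nM
compound 3 `O=C(Nc1cccc(Cl)c1)Nc1cc2ncncc2cc1OCc1cccc(Cl)c1`: 3500 nM

Compound 3 (3500 nM) stands in the middle of these three numbers, and its gaps to compound 1 and to compound 2 both lie within the scatter. The series therefore shows little spread so far.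

The next compound to be tested is compound 4 `O=C(Nc1cccc(F)c1)Nc1cc2ncncc2cc1OCc1cccc(Cl)c1`. It departs from compound 3 by one exchange, fluoro in place of chloro on an aromatic carbon, with 3-fluorophenyl replacing 3-chlorophenyl on the urea side: fluoro in place of chloro on an aromatic carbon.

Among the compounds with values here, only one measured step links two compounds that differ in a single place. That step, a 1.3-fold higher number from compound 1 to compound 3 (0.10 log units; within the scatter), lies within the scatter, but it does not touch the group changed here. Compound 2 (5900 nM) also carries a fluoro, but it differs from compound 3 in more than one place, so it offers no clean comparison. Within the data shown here, no measured step exchanges chloro for fluoro.

With so little to go on, no shift beyond the scatter is expected in this assay. The expected step is small, a 1.1-fold higher number from compound 3 to compound 4 (0.04 log units; within the scatter), with no firm direction. For compound 4 the estimate is 3800 nM, with an expected range of 1900 nM to 7500 nM.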

Compound 4, half-maximal inhibitory concentration: 8300 nM
Compound 4: middle estimate off by 2.2-fold (0.34 log units), on the low side; the whole stated range lies below it.
By their numbers in this assay, from the lowest: compounds 1, 3, 2 and 4 (each within the scatter of the next, the first and the last beyond it).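

In this assay, within the data shown here, the change from 3-chlorophenyl to 3-fluorophenyl gives a 2.4-fold higher number from compound 3 to compound 4 (0.38 log units; beyond the scatter) and is the first single-place step to pass beyond the scatter. Among these compounds, the only earlier step of this kind, a 1.3-fold higher number from compound 1 to compound 3 (0.10 log units; within the scatter) and within the scatter, moved a chlorine on the other phenyl ring, so it said nothing about this ring; the new step shows that the number here can respond to the exchange of a single halogen atom on an aromatic carbon, meta to a large group, with no change in ring, net charge or counted hydrogen-bond donors and acceptors. The size of this step is modest, and no measurement in hand explains why this exchange gives a weaker inhibitor.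

This single pair cannot show whether the step follows a trend across substituents at this carbon, such as bromo, methyl, methoxy or trifluoromethyl, or how the unsubstituted phenyl would compare. It also leaves open whether the same exchange of chloro for fluoro would give a similar step on the other phenyl ring.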